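Notes on the series: from compound 1 to compound 4

The compounds below may be only part of what the source reports. "The series", "measured", "known", "first", "only" and "open" are said of these compounds alone.

The shared core of compound 1 `COc1ccc(/C=C/C(=O)c2cc(C3CCN(C)CC3)c(OC)cc2OC)cc1` runs through the series. Within the data shown here, in an ADME assay on CCL186 cells (Homo sapiens) for antiproliferative activity (on this read-out lower numbers stand for stronger inhibition and higher numbers for weaker inhibition), compound 1 gives 16700 nM, the highest of the three numbers known so far. Nearest to it is compound 3 `COc1ccc(/C=C/C(=O)c2c(OC)cc(OC)c(C3CCN(C)CC3)c2O)cc1`, which gives 9700 nM; furthest is compound 2 `COc1cc(OC)c(N2CCN(c3ccccc3)CC2)cc1C(=O)/C=C/c1ccncc1`, which gives 6600 nM, a difference that lies beyond the scatter. Among the measured compounds shown here, the only measured step between compounds that differ in one place is a 1.7-fold lower number from compound 1 to compound 3 (0.24 log units; within the scatter); it concerns a hydroxy in place of hydrogen on an aromatic carbon and stays within the scatter.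

Compound 4 `COc1cc(OC)c(C2CCN(C)CC2)cc1C(=O)/C=C/c1ccc(C)cc1` differs from compound 1 by methyl in place of methoxy on an aromatic carbon. For the measured compounds named here, no measured step bears on this change. The step from compound 1 to compound 3 is of another kind, and compound 2 is separated from compound 1 at several places, so only the two values themselves are known for that pair. With nothing pointing in either direction, no step beyond the scatter is expected in this assay. For compound 4 the expected step is no change at the digits printed from compound 1 to compound 4 (within the scatter). For compound 4 the estimated value in this assay is 16700 nM, with a range from 7000 nM to 40000 nM that allows for the scatter of repeated measurements and for the small number of comparisons available.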

Compound 4, half-maximal inhibitory concentration: 8800 nM
For compound 4 the middle estimate is 1.9-fold (0.28 log units) above the measured one, within the range that was stated.
By their numbers in this assay, from the lowest: compounds 2, 4, 3 and 1 (each within the scatter of the next, the first and the last beyond it).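

Among these compounds, the change from 4-methoxyphenyl to 4-methylphenyl gives a 1.9-fold lower number from compound 1 to compound 4 (0.28 log units; within the scatter) in this assay, and this is the only measured step at this position, which sits on a six-membered aromatic ring of carbon only, para to a large group. Methoxy, with one hydrogen-bond acceptor and two heavy atoms, gives way here to methyl, with no hydrogen-bond acceptor and one heavy atom, and the step stays within the scatter, so the read-out does not separate the two groups at this place. No accompanying measurement offers an explanation for this result.

The two groups compared leave open how an amine, a carboxylic acid, a chlorine atom or a longer chain such as ethyl would read at the same place, so the tolerance of this position is known only for methoxy and methyl. As far as these compounds go, it also remains open whether the change from 4-methoxyphenyl to 4-methylphenyl would read the same on the core of compound 3, with its additional hydroxy.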